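Removing the Methyl from the Aromatic Ether

The compounds below may be only part of what the source reports. "The series", "measured", "known", "first", "only" and "open" are said of these compounds alone.

Compound 2 `COc1ccc(-c2nc3c(NC4CCCC4)ncnc3n2C)cc1` gives 1850 nM in an assay on CHO cells for displacement of a labelled ligand from adenosine receptor A3 (Homo sapiens), read by scintillation counting, with a stated time of 3 h; a higher number here means a weaker inhibitor, a lower number a stronger inhibitor. Compound 1 `Cn1c(-c2ccc(F)cc2)nc2c(NC3CCCC3)ncnc21` gives 1140 nM in this assay, and the step of a 1.6-fold higher number from compound 1 to compound 2 (0.21 log units; within the scatter) lies within the scatter, so on the numbers shown compound 2 cannot be told apart from compound 1. Compound 3 `Cn1c(-c2ccc(O)cc2)nc2c(NC3CCCC3)ncnc21` differs from compound 2 by hydrogen in place of methyl on an oxygen on an aromatic ring. Going by the values given here, only that one measured step bears on this change; it swapped a group at the same ring position and did not move the number beyond the scatter. The step of a 1.2-fold lower number from compound 2 to compound 3 (0.09 log units; within the scatter) is therefore expected to stay within the scatter. Compound 3 is estimated at 1500 nM in this assay, with a range from 500 nM to 5000 nM.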

Compound 3, inhibition constant: 521 nM
The estimate for compound 3 lay 2.9-fold (0.46 log units) above the measured number; the range from low to high includes it.
By their numbers in this assay, from the lowest: compound 3; then compounds 1 and 2 (each within the scatter of the next).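

Unlike the earlier swap of fluoro for methoxy, this change moves the number beyond the scatter in this assay: removing the methyl from the oxygen gives a clear step (a 3.6-fold lower number from compound 2 to compound 3 (0.55 log units; beyond the scatter)), and hydroxy in place of fluoro gives another (a 2.2-fold lower number from compound 1 to compound 3 (0.34 log units; beyond the scatter)). Both steps are modest, but they show that this position can respond to the group it carries. Nothing shown here explains why the hydroxy compound gives the lower number.

As far as these compounds go, it remains open how an amine or a carboxylic acid at this place would compare with the hydroxy. A longer chain on the oxygen, such as ethoxy, is equally untested among the compounds shown.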